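The source may report more compounds than this note shows. Statements on the series, on what has been measured and on what is new or still open speak of the compounds shown alone.

Compound 1 `COc1cc(-c2nnc3n2NC(c2ccco2)C(C(=O)c2ccccc2F)S3)cc(OC)c1OC` sits at the edge of what a functional assay on PC-3 cells (Homo sapiens) for cytotoxicity, read by MTT assay, with a stated time of 48 h (a higher number here means a weaker inhibitor, a lower number a stronger inhibitor), can report: in this assay compound 1 gives > 100000 nM, which is a limit rather than a number. Compound 2 `COc1cc(-c2nnc3n2NC(c2ccco2)C(C(=O)c2cccc4ccccc24)S3)cc(OC)c1OC` gives > 100000 nM in this assay, likewise a limit. The step that the two limits leave unreadable from compound 1 to compound 2 is therefore unreadable, and the limit of > 100000 nM in this assay, at which 2 of the 2 values shown sit, is all the series shows so far. Compound 3 `COc1cc(-c2nnc3n2NC(c2ccco2)C(C(=O)c2ccc([N+](=O)[O-])cc2)S3)cc(OC)c1OC` differs from compound 1 by 4-nitrophenyl in place of 2-fluorophenyl on a carbonyl carbon. Going by the values given here, no measured step bears readably on this change, so the step of a number no higher from compound 1 to compound 3 (the limit leaves the size open) is expected to stay within the scatter. For compound 3 an estimate of 100000 nM, with a range of 30000 nM to 300000 nM, is made, most probably again reported only as a limit.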

Compound 3, half-maximal inhibitory concentration: 27900 nM
Beside the measured number, compound 3's estimate is 3.6-fold (0.55 log units) above it, outside the stated range (below it).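

In this assay, the carbonyl carbon's aryl group proves able to move the read-out: 4-nitrophenyl gives an at least 3.5-fold lower number from compound 1 to compound 3 (0.55 log units; beyond the scatter), and replacing naphthalen-1-yl with it gives an at least 3.5-fold lower number from compound 2 to compound 3 (0.55 log units; beyond the scatter). Both sizes are open-ended, as each starts from a limit. Compound 3 is the only one of the three with a number, and the other two stay at the limit: the limit of > 100000 nM in this assay, at which 2 of the 3 values shown sit.

Going by these compounds, whether the nitro group itself carries the step stays open, since no plain phenyl, 4-aminophenyl or 4-carboxyphenyl stands beside it. On these data alone, how far the number can fall at this position also remains open.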